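The compounds below may be only part of what the source reports. "The series", "measured", "known", "first", "only" and "open" are said of these compounds alone.

In a functional assay on HepG2 cells (Homo sapiens) for inhibition, read by MTT assay, with a stated time of 72 h (a higher number here means a weaker inhibitor, a lower number a stronger inhibitor), compound 1 `Cc1cc2occ(-c3nc(-c4ccccc4)c(-c4ccccc4)n3-c3ccc([N+](=O)[O-])cc3)c(=O)c2cc1Cl` gives 25000 nM, compound 2 `Cc1cc2occ(-c3nc(-c4ccccc4)c(-c4ccccc4)n3-c3ccc(Cl)c(Cl)c3)c(=O)c2cc1Cl` gives 12500 nM and compound 3 `Cc1cccc(-n2c(-c3coc4cc(C)c(Cl)cc4c3=O)nc(-c3ccccc3)c2-c2ccccc2)c1` gives 6250 nM. Compound 3 stands clear of only one of these, with a 4.0-fold lower number from compound 1 to compound 3 (0.60 log units; beyond the scatter), whereas a 2.0-fold lower number from compound 2 to compound 3 (0.30 log units; within the scatter) does not separate it from its nearest neighbour. Compound 4 `Cc1cc2occ(-c3nc(-c4ccccc4)c(-c4ccccc4)n3-c3ccc(Cl)cc3)c(=O)c2cc1Cl` has 4-chlorophenyl in place of 3-methylphenyl on an aromatic nitrogen. The closest guide is compound 2, whose group at this place also carries chlorine and which gives 12500 nM. The same exchange in reverse, a 2.0-fold lower number from compound 2 to compound 3 (0.30 log units; within the scatter), suggests little movement, so the expected result is a small shift toward a higher number, not beyond the scatter: a 2.0-fold higher number from compound 3 to compound 4 (0.30 log units; within the scatter). The estimate for compound 4 is 12500 nM, with an expected range of 5000 nM to 28000 nM.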

Compound 4, half-maximal inhibitory concentration: 1560 nM
Compound 4: middle estimate off by 8.0-fold (0.90 log units), on the high side; the whole stated range lies above it.
By their numbers in this assay, from the lowest: compound 4; then compounds 3, 2 and 1 (each within the scatter of the next, the first and the last beyond it).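

In this assay, for the compounds shown here, there is a 4.0-fold lower number from compound 3 to compound 4 (0.60 log units; beyond the scatter) on moving to 4-chlorophenyl, and compound 4 is the only compound whose steps to all the others lie beyond the scatter. Removing a single chloro from the 3,4-dichlorophenyl group gives an 8.0-fold lower number from compound 2 to compound 4 (0.90 log units; beyond the scatter) and chloro in place of nitro gives a 16-fold lower number from compound 1 to compound 4 (1.20 log units; beyond the scatter) as well, so one substituent on this ring moves the number further than any earlier step did. Nothing measured here accounts for these steps. From the compounds shown here alone, what an amine or a methoxy group in place of this chloro would give stays open, and so does whether the steps would hold with a carboxylic acid elsewhere on the shared core.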